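A few compounds are considered here, and "the series" means these few. Any claim that something is new, unique, unknown or untested is made for them only; others in the source may bear on it.

Compound 3 `Cc1cccc(C)c1C(=O)OC1CCN(C)CC1`, tested in a functional assay on the whole organism with Mus musculus as the target (a higher number here means a more potent compound, by a factor of ten per unit of this negative logarithm, a lower number a less potent compound), gives 1.27. Compound 2 `Cc1ccc(C)c(C(=O)OC2CCN(C)CC2)c1` gives 1.36 in this assay, and compound 1 `Cc1cc(C)c(C(=O)OC2CCN(C)CC2)cc1C` gives 1.17; the difference between the cores of compound 2 and compound 3 is not broken down here. Going a number 0.19 log units lower from compound 2 to compound 1 (within the scatter), the change is methyl in place of hydrogen on an aromatic carbon. Compound 4 `Cc1cc(C)c(C(=O)OC2CCN(C)CC2)c(C)c1` differs from compound 3 by methyl in place of hydrogen on an aromatic carbon. The two places are not identical: in the first the entering methyl sits ortho to a methyl group and meta to a methyl group, in the second meta to two methyl groups, so this is the same kind of change, not the same. The account expects a step of a number 0.12 log units lower from compound 3 to compound 4 (within the scatter), resting on the earlier step of a number 0.19 log units lower from compound 2 to compound 1 (within the scatter). Compound 4 is therefore estimated at 1.15, between 0.75 and 1.55.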

Compound 4, logarithm of the reciprocal of the active concentration, log(1/C): 1.55
Estimate against measurement, compound 4: 0.40 log units below; the range from low to high includes it.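

Going a number 0.28 log units higher from compound 3 to compound 4 (within the scatter), the methyl in place of hydrogen on an aromatic carbon in this assay does not repeat the step seen on the other core, and the two steps do not agree: the same change on two cores in this assay, a number 0.19 log units lower (within the scatter) from compound 2 to compound 1 and a number 0.28 log units higher (within the scatter) from compound 3 to compound 4, 0.47 log units apart, beyond the scatter of two such steps On these two cores, then, this change cannot be carried over as a fixed amount, so a step read on one core gives a poor guide to the other. Going by these compounds alone, this does not show why the steps differ, since each alone lies within the scatter, the two places are not identical, and each core offers only one such pair.

The compounds shown leave open how a methoxy group, a chlorine atom or an amine would behave in place of this methyl. They also leave open whether such a step would depend on the core in the same way.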